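A few compounds are considered here, and "the series" means these few. Any claim that something is new, unique, unknown or untested is made for them only; others in the source may bear on it.

Measured so far:
compound 1 `CC1CCCN(c2nc(Cc3c(F)cccc3F)cc(=O)[nH]2)C1`, > 78000 nM
compound 2 `Cc1c(Cc2c(F)cccc2F)nc(N2CCCC(C)C2)[nH]c1=O`, > 75000 nM
compound 3 `CC(c1cc(=O)[nH]c(N(C)C)n1)c1c(F)cccc1F`, 89000 nM

In an ADME assay on MT4 cells (Homo sapiens) for cytotoxicity, read by MTT assay, with a stated time of 4 days (on this read-out lower numbers stand for higher toxicity in this test and higher numbers for lower toxicity in this test), compound 1 gives > 78000 nM, a limit of the assay rather than a number. Compound 2 gives > 75000 nM, also a limit. Going by the values given here, compound 3 gives 89000 nM, the only number among the three. The step that the two limits leave unreadable from compound 1 to compound 2 stays unreadable because the limit of > 75000 nM in this assay, at which 1 of the 3 values shown sits, and the limit of > 78000 nM in this assay, at which 1 of the 3 values shown sits, bound it; the change is methyl in place of hydrogen on an aromatic carbon.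

Compound 4 `Cc1c(C(C)c2c(F)cccc2F)nc(N(C)C)[nH]c1=O` is not yet measured. It differs from compound 3 by methyl in place of hydrogen on an aromatic carbon, the same kind of change as from compound 1 to compound 2, but the surroundings differ: there the methyl sits ortho to a group of 9 heavy atoms and para to a 3-methylpiperidin-1-yl group, here ortho to a large group and para to a dimethylamino group. The difference between the two cores is not broken down here.

With no measured size to lean on, the step from compound 3 to compound 4 in this assay is expected to be small, a 1.0-fold lower number from compound 3 to compound 4 (0.02 log units; within the scatter). Compound 4 is estimated at 85000 nM, between 40000 nM and 180000 nM, with a real chance that only a limit is reported.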

Compound 4, half-maximal cytotoxic concentration: > 17000 nM
Compound 4: no number, only a limit; the forecaster's own chance of this, stated with the estimate: 55%; the middle value lies beyond the limit too.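

In this assay compound 4 gives > 17000 nM, a limit and not a number, and the step from compound 3 to compound 4 cannot be read. On these data alone, whether methyl in place of hydrogen on an aromatic carbon shifts the half-maximal cytotoxic concentration at all stays open for both pairs, compound 1 with compound 2 and compound 3 with compound 4.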